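The source may report more compounds than this note shows. Statements on the series, on what has been measured and on what is new or still open speak of the compounds shown alone.

In a functional assay on MDA-MB-231 cells (Homo sapiens) for antiproliferative activity, read by MTT assay, with a stated time of 72 h (a lower number here means a stronger inhibitor, a higher number a weaker inhibitor), compound 2 `Cc1ccc(NC(=O)c2cnc(C(C)(C)C)s2)cc1C#Cc1nn(C[C@@H](C)CO)c2ncnc(N)c12` gives 34 nM, the lowest of the two numbers recorded, while compound 1 `Cc1ccc(C(=O)Nc2cccc(C(F)(F)F)c2)cc1C#Cc1nn(CC2CCN(C)CC2)c2ncnc(N)c12` gives 70 nM, a higher number that lies beyond the usual scatter. Within the data shown here, compound 1 and compound 2 differ in more than one place, so no single step between them is counted. Compound 3 `Cc1ccc(NC(=O)c2ccc(Cl)c(C(F)(F)F)c2)cc1C#Cc1nn(C[C@@H](C)CO)c2ncnc(N)c12` has not yet been measured in this assay. It differs from compound 2 in one place: 4-chloro-3-(trifluoromethyl)phenyl in place of 2-(tert-butyl)-1,3-thiazol-5-yl on a carbonyl carbon. Among the measured compounds shown here, with no counted step to lean on, the expectation rests on the two measured numbers alone. Compound 1 carries a trifluoromethylphenyl group on its amide and gives 70 nM, so a comparable aryl amide on the core of compound 2 is expected to stay in the same region. The step from compound 2 to compound 3 is expected to be a 1.3-fold higher number from compound 2 to compound 3 (0.12 log units; within the scatter), no larger than the scatter or slightly weakening. Compound 3 is expected to give about 45 nM, within a range from 15 nM to 130 nM.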

Compound 3, half-maximal inhibitory concentration: 23 nM
Beside the measured number, compound 3's estimate is 2.0-fold (0.29 log units) above it, within the range that was stated.
By their numbers in this assay, from the lowest: compounds 3 and 2 (each within the scatter of the next); then compound 1.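

In this assay the place on the carbonyl carbon whose other neighbour is the amide-type nitrogen accepts two quite different groups: 4-chloro-3-(trifluoromethyl)phenyl in place of 2-(tert-butyl)-1,3-thiazol-5-yl gives a 1.5-fold lower number from compound 2 to compound 3 (0.17 log units; within the scatter) and so does not separate the two compounds. Among these compounds, this is the first comparison here that changes only one place, and it shows that a five-membered aromatic ring with hetero atoms and a six-membered aromatic ring of carbon only can each stand there on the same core with no change beyond the scatter. Nothing available explains why these two groups give such similar numbers.

On these data alone, whether this place needs an aromatic ring at all remains open, as a cyclohexyl group or an open butyl chain on the same carbonyl carbon could show. The separate contributions of the several features that set compound 1 apart also cannot be read from these compounds.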